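Ureidopyrimidine series: piperazine variants at the amino position

The source may hold more compounds than are shown below. What is called first, only, known or untested is meant among the compounds shown, and "the series" means these compounds.

Measured compounds in a functional assay on PC-3 cells (Homo sapiens) for inhibition, with a stated time of 72 h; a lower number here means a stronger inhibitor, a higher number a weaker inhibitor:
compound 1 `O=C(Nc1ccccc1)Nc1nc(NC2CC2)cc(Sc2c[nH]c3ccccc23)n1`: 17500 nM
compound 2 `O=C(Nc1ccccc1)Nc1nc(Sc2c[nH]c3ccccc23)cc(N2CCN(Cc3ccccc3)CC2)n1`: 42500 nM
compound 3 `O=C(Nc1ccccc1)Nc1nc(Nc2ccc(Cl)cc2)cc(Sc2c[nH]c3ccccc23)n1`: 32300 nM

Compound 3 gives the second highest of the three numbers; its value and that of compound 2 lie within the scatter, as do its value and that of compound 1. For the measured compounds named here, the one step that exists within the measured set is a 1.8-fold higher number from compound 1 to compound 3 (0.27 log units; within the scatter), which is within the scatter.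

Compound 4 `O=C(Nc1ccccc1)Nc1nc(Sc2c[nH]c3ccccc23)cc(N2CCN(c3ccccn3)CC2)n1` differs from compound 3 by 4-(pyridin-2-yl)piperazin-1-yl in place of (4-chlorophenyl)amino on an aromatic carbon. Going by the values given here, no measured step covers this exact change. Among the compounds with values here, compound 2, which carries a benzyl-substituted piperazine in the same place, and compound 3 show values within the scatter of each other, so nothing among the measured compounds points to a step beyond the scatter in this assay. A step of about a 1.2-fold higher number from compound 3 to compound 4 (0.09 log units; within the scatter) is therefore expected, which is none beyond the scatter. Compound 4 is estimated at 40000 nM, with a range from 15000 nM to 110000 nM.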

Compound 4, half-maximal inhibitory concentration: 21600 nM
Compound 4: the middle estimate sits 1.9-fold (0.27 log units) above what was measured; the range from low to high includes it.
By their numbers in this assay, from the lowest: compounds 1, 4, 3 and 2 (each within the scatter of the next, the first and the last beyond it).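

In this assay, 4-(pyridin-2-yl)piperazin-1-yl in place of (4-chlorophenyl)amino gives a 1.5-fold lower number from compound 3 to compound 4 (0.17 log units; within the scatter), and in place of cyclopropylamino it gives a 1.2-fold higher number from compound 1 to compound 4 (0.09 log units; within the scatter); this position thus accepts the piperazine, and the loss of the hydrogen-bond donor of (4-chlorophenyl)amino, with no step beyond the scatter. On the piperazine itself, pyridin-2-yl in place of benzyl on the amine nitrogen gives a 2.0-fold lower number from compound 2 to compound 4 (0.29 log units; within the scatter), so these two substituents are not told apart in this assay. Nothing measured here bears on the reason for these results.

Still open, from the compounds shown here alone, is whether a morpholine at this position, or an unsubstituted piperazine with its free amine, would give a step beyond the scatter. Also open, going by these compounds, is whether a carboxylic acid on the piperazine nitrogen would do so.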